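The source may report more compounds than this note shows. Statements on the series, on what has been measured and on what is new or still open speak of the compounds shown alone.

Compound 1 `Cc1ccc(C(=O)NNC(=S)Nc2csc(-c3ccccc3)c2)cc1` gives 62000 nM in a functional assay on U-373MG ATCC cells (Homo sapiens) for inhibition, read by colorimetric assay and MTT assay, with a stated time of 72 h; on this read-out lower numbers stand for stronger inhibition and higher numbers for weaker inhibition.
Compound 2 `COc1ccc(C(=O)NNC(=S)Nc2csc(-c3ccccc3)c2)cc1` gives 41000 nM in this assay.
Compound 3 `Cc1ccc(-c2nnc(Nc3csc(-c4ccccc4)c3)s2)cc1` gives only a limit of the assay, > 100000 nM in this assay.

The change from compound 1 to compound 2 is methoxy in place of methyl on an aromatic carbon, and it made a step of a 1.5-fold lower number from compound 1 to compound 2 (0.18 log units; within the scatter). The core of compound 3 differs from the core of compound 1, but that difference is not broken down here. Compound 4 `COc1ccc(-c2nnc(Nc3csc(-c4ccccc4)c3)s2)cc1` is not yet measured in this assay; it differs from compound 3 by methoxy in place of methyl on an aromatic carbon, the same change as the earlier one, which occurs twice among these compounds. Compound 4 is therefore expected to move by about a step that the limit leaves unreadable from compound 3 to compound 4. That expectation rests on the earlier step, a 1.5-fold lower number from compound 1 to compound 2 (0.18 log units; within the scatter), and on compound 3 sitting at the limit of > 100000 nM in this assay, at which 1 of the 3 values shown sits, so a limit is again likely. Compound 4 is estimated at 130000 nM, between 50000 nM and 400000 nM.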

Compound 4, half-maximal inhibitory concentration: 92000 nM
For compound 4 the middle estimate is 1.4-fold (0.15 log units) above the measured one; the range from low to high includes it.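

In this assay, the change from 4-methylphenyl to 4-methoxyphenyl on the core of compound 3 gives an at least 1.0-fold lower number from compound 3 to compound 4 (0.03 log units; that floor lies within the scatter). Compound 3 gives only a limit of the assay, > 100000 nM, so this step is a floor and not a full size. The change can be set beside its counterpart on the core of compound 1, but this shows neither that it carries over by the same amount nor that it behaves differently: the same change on two cores in this assay, a 1.5-fold lower number (0.18 log units; within the scatter) from compound 1 to compound 2 and an at least 1.0-fold lower number (0.03 log units; that floor lies within the scatter) from compound 3 to compound 4; the limit leaves it open whether they differ

The compounds shown leave open whether another group at this place, such as an amine, a carboxylic acid or a longer chain, would give a step beyond the scatter. They also leave open how the methoxy change behaves on any core other than these two.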